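Swapping a Chlorophenyl for Pyridinyl on the Pyrrole Nitrogen

This account rests on a few compounds, and the source may have more. Where it says the series, first, only, none or still open, it means among the compounds named here.

Measured so far:
compound 1 `CCOC(=O)C1=C(O)/C(=C\c2cc(C)n(-c3ccc(F)cc3)c2C)N=C1C` gives 94 mL.min-1.g-1
compound 2 `CCOC(=O)C1=C(C)N/C(=C/c2cc(C)n(-c3ccc(Cl)cc3)c2C)C1=O` gives 72 mL.min-1.g-1

Two compounds have been run in an ADME assay on microsomes from liver (Mus musculus) for metabolic stability, read by LC-MS, tested at 1 uM; a lower number here means slower removal, a higher number faster removal of the compound. Compound 1 `CCOC(=O)C1=C(O)/C(=C\c2cc(C)n(-c3ccc(F)cc3)c2C)N=C1C` gives 94 mL.min-1.g-1, and compound 2 `CCOC(=O)C1=C(C)N/C(=C/c2cc(C)n(-c3ccc(Cl)cc3)c2C)C1=O` gives 72 mL.min-1.g-1. Compound 2 carries the lower of the two numbers, but the gap to compound 1 lies within the scatter of this assay, so no order between them can be claimed.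

The next compound, compound 3 `CCOC(=O)C1=C(C)N/C(=C/c2cc(C)n(-c3ccncc3)c2C)C1=O`, differs from compound 2 in one place: pyridin-4-yl in place of 4-chlorophenyl on an aromatic nitrogen. Within the data shown here, no measured pair in this set shows the effect of such a change, so the expectation rests only on compound 2 itself.

Compound 3 is expected to show a modest step downward in this assay, a 1.6-fold lower number from compound 2 to compound 3 (0.20 log units; within the scatter), though a step no larger than the scatter would not surprise. The estimate for compound 3 is 45 mL.min-1.g-1, with a range from 18 mL.min-1.g-1 to 110 mL.min-1.g-1.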

Compound 3, intrinsic clearance in microsomes: 61 mL.min-1.g-1
Compound 3: middle estimate off by 1.4-fold (0.13 log units), on the low side; measured number inside the range.
By their numbers in this assay, from the lowest: compounds 3, 2 and 1 (each within the scatter of the next).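

In this assay, among these compounds, this is the first comparison in the set that differs in one place: pyridin-4-yl in place of 4-chlorophenyl on the aromatic nitrogen gives a 1.2-fold lower number from compound 2 to compound 3 (0.07 log units; within the scatter). The step shows that, at this position, a six-membered aromatic ring with a hetero atom and a hydrogen-bond acceptor can stand in for a ring of carbon only without a difference that this measurement can resolve. Nothing at hand explains this result.

From the compounds shown here alone, it remains open whether a pyridin-3-yl group, a morpholine or a carboxylic acid carried on the ring at this nitrogen would give a step beyond the scatter. The compounds shown also leave open whether a change elsewhere on the shared core would move the number further than this exchange did.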